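This account rests on a few compounds, and the source may have more. Where it says the series, first, only, none or still open, it means among the compounds named here.

Measured compounds in the series:

Compound 1, `NCCCCNc1nc(Nc2ccc(Oc3nccs3)cc2)c2ncn(C3CCCC3)c2n1` — 18600 nM
Compound 2, `OCCCCNc1nc(Nc2ccc(Oc3nccs3)cc2)c2ncn(C3CCCC3)c2n1` — 23500 nM
Compound 3, `NCCCCNc1nc(Nc2ccc(N3CCN(Cc4ccccc4)CC3)cc2)c2ncn(C3CCC(O)C3)c2n1` — 13200 nM

All three were read in an ADME assay on BJ cells (Homo sapiens) for inhibition, read by fluorescence and resazurin assay, with a stated time of 72 h; a lower number here means a stronger inhibitor of growth, a higher number a weaker inhibitor of growth. Compound 1 and compound 2 share one core and differ by hydroxy in place of amino on a saturated chain carbon, four bonds along the chain from a nitrogen on an aromatic ring. For the measured compounds named here, the step of a 1.3-fold higher number from compound 1 to compound 2 (0.10 log units; within the scatter) is the only measured instance of this change so far. Compound 3 carries a different core; the difference between the two cores is not broken down here. In this assay compound 3 gives 13200 nM, which sits within the scatter of both compound 1 and compound 2, so no order among the three can be claimed.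

Compound 4, `OCCCCNc1nc(Nc2ccc(N3CCN(Cc4ccccc4)CC3)cc2)c2ncn(C3CCC(O)C3)c2n1`, is not yet measured. It differs from compound 3 by hydroxy in place of amino on a saturated chain carbon, four bonds along the chain from a nitrogen on an aromatic ring, the same kind of change as from compound 1 to compound 2, at the same place. The expectation rests on a single precedent, the step of a 1.3-fold higher number from compound 1 to compound 2 (0.10 log units; within the scatter), and on the value of compound 3, 13200 nM. The step from compound 3 to compound 4 is expected to be a 1.3-fold higher number from compound 3 to compound 4 (0.10 log units; within the scatter), small and within the scatter, because a 1.3-fold higher number from compound 1 to compound 2 (0.10 log units; within the scatter) was small. Compound 4 is estimated at 16500 nM, with a range from 8000 nM to 35000 nM.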

Compound 4, concentration for 50% growth inhibition: 23800 nM
For compound 4 the middle estimate is 1.4-fold (0.16 log units) below the measured one; measured number inside the range.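

In this assay, hydroxy in place of amino on a saturated chain carbon, four bonds along the chain from a nitrogen on an aromatic ring, has now been read on two cores, and the new step is a 1.8-fold higher number from compound 3 to compound 4 (0.26 log units; within the scatter). The two steps do not differ beyond what repeated measurement allows, so the change reads alike on these two cores: the same change on two cores in this assay, a 1.3-fold higher number (0.10 log units; within the scatter) from compound 1 to compound 2 and a 1.8-fold higher number (0.26 log units; within the scatter) from compound 3 to compound 4, 1.4-fold (0.15 log units) apart, within the scatter of two such steps. Since each step lies within the scatter, neither shows that the change itself moves the number, and two pairs do not make a rule for the series.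

From the compounds shown here alone, it remains open how a carboxylic acid, a dimethylamino group or a methoxy group in place of the amino or hydroxy group would read, and whether a longer chain would alter the picture. Also open, going by these compounds, is how the same change reads on any other core or in any other assay.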